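This account rests on a few compounds, and the source may have more. Where it says the series, first, only, none or still open, it means among the compounds named here.

Measured in a functional assay on HepG2 cells (Homo sapiens) for inhibition, read by MTT assay, with a stated time of 48 h; on this read-out lower numbers stand for stronger inhibition of growth and higher numbers for weaker inhibition of growth:
Compound 1 `Cn1cc(C2CC(c3ccccc3)=NN2C(=O)c2cccnc2)c2ccccc21`: 4630 nM
Compound 2 `Cn1cc(C2CC(c3ccccc3)=NN2C(=O)c2cccnc2)c2cc(Br)ccc21`: 2520 nM
Compound 3 `COc1ccc2c(c1)c(C1CC(c3ccc(Cl)cc3)=NN1C(=O)c1ccc(OC)nc1)cn2C`: 2080 nM

Compound 3, at 2080 nM, lies within the usual scatter of compound 2, at 2520 nM. Only compound 1, at 4630 nM, stands beyond the scatter from compound 3, with the higher number.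

The next compound is compound 4 `COc1cccc(C2=NN(C(=O)c3ccc(OC)nc3)C(c3cn(C)c4ccc(OC)cc34)C2)c1`, which carries 3-methoxyphenyl in place of 4-chlorophenyl on a carbon with a double bond to nitrogen. Going by the values given here, no measured pair shows a change at that place. Among the compounds with values here, the one step available, a 1.8-fold lower number from compound 1 to compound 2 (0.26 log units; within the scatter), is a different change, and it stays within the scatter. It gives no direction and no size for this swap, so no step beyond the scatter is expected in this assay. The expectation therefore rests on compound 3 at 2080 nM, with a wide margin since the data are so few. The expected step is small, a 1.2-fold higher number from compound 3 to compound 4 (0.08 log units; within the scatter), and this is an estimate that does not go beyond the scatter. For compound 4 the estimated value is 2500 nM, with an expected range of 1100 nM to 6000 nM.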

Compound 4, concentration for 50% growth inhibition: 190 nM
For compound 4 the middle estimate is 13-fold (1.12 log units) above the measured one; the whole stated range lies above it.
By their numbers in this assay, from the lowest: compound 4; then compounds 3, 2 and 1 (each within the scatter of the next, the first and the last beyond it).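

In this assay the group on the carbon with a double bond to nitrogen proves to be a place where the read-out responds strongly: 3-methoxyphenyl in place of 4-chlorophenyl gives an 11-fold lower number from compound 3 to compound 4 (1.04 log units; beyond the scatter) on an otherwise unchanged core. Going by these compounds alone, the earlier compounds offered no pair that changed at this place, and their one step, the bromo in place of hydrogen with a 1.8-fold lower number from compound 1 to compound 2 (0.26 log units; within the scatter), could not show that any single change reaches beyond the scatter. Nothing available accounts for the size of this step, so it stands as an observation without an explanation.

The swap alters two things at once, the substituent itself and where it sits on the phenyl ring, so the compounds shown cannot tell whether the methoxy group, its place on the ring or the loss of the chlorine carries the step, and a comparison with 3-chlorophenyl or 4-methoxyphenyl at this carbon remains open. On these data alone, it is also open whether a longer chain, as in 3-ethoxyphenyl, or an amine, as in 3-aminophenyl, would keep the lower number at this place.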